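A Hydroxyalkyl Group Replaces a Lactam at One Position

The source may hold more compounds than are shown below. What is called first, only, known or untested is meant among the compounds shown, and "the series" means these compounds.

Measured so far:
Compound 1, `CCCCCNc1cccc2c(S(=O)(=O)Nc3onc(C)c3C)cccc12`: 80 nM
Compound 2, `Cc1noc(NS(=O)(=O)c2cccc3c(N4CCCC4=O)cccc23)c1C`: 130 nM

In an assay on VSM-A10 cells for antagonist activity at Endothelin-1 receptor (Rattus norvegicus) (on this read-out higher numbers stand for weaker inhibition and lower numbers for stronger inhibition), compound 2 gives 130 nM. Compound 1 gives 80 nM in this assay. Among the measured compounds shown here, compound 2 therefore stands at the higher of the two numbers, but its only neighbour is compound 1, and the step of a 1.6-fold higher number from compound 1 to compound 2 (0.21 log units; within the scatter) is within the scatter, so the two cannot be ranked.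

Compound 3, `Cc1noc(NS(=O)(=O)c2cccc3c(C(C)(C)O)cccc23)c1C`, is the next compound, not yet measured in this assay. Its change from compound 2 is 1-hydroxy-1-methylethyl in place of 2-oxopyrrolidin-1-yl on an aromatic carbon. For the measured compounds named here, the one measured step that bears on it is the change at the same aromatic carbon from pentylamino to 2-oxopyrrolidin-1-yl, a 1.6-fold higher number from compound 1 to compound 2 (0.21 log units; within the scatter), which stayed within the scatter. Two quite different groups at this place gave much the same number, so the smaller 1-hydroxy-1-methylethyl group is expected to leave the number roughly where it is, with a step of no change at the digits printed from compound 2 to compound 3 (within the scatter) that is not expected to pass beyond the scatter. Compound 3 is estimated at 130 nM, with a range from 50 nM to 350 nM.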

Compound 3, half-maximal inhibitory concentration: 2890 nM
Beside the measured number, compound 3's estimate is 22-fold (1.35 log units) below it; measured number outside the range, above it.
By their numbers in this assay, from the lowest: compounds 1 and 2 (each within the scatter of the next); then compound 3.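

In this assay, the position proves far from indifferent to what it carries, although the first pair gave no sign of this: putting 1-hydroxy-1-methylethyl in place of 2-oxopyrrolidin-1-yl gives a 22-fold higher number from compound 2 to compound 3 (1.35 log units; beyond the scatter), and putting it in place of pentylamino gives a 36-fold higher number from compound 1 to compound 3 (1.56 log units; beyond the scatter). The two groups that could not be ranked against each other, pentylamino and 2-oxopyrrolidin-1-yl, both join the aromatic carbon through nitrogen, whereas the entering group joins it through carbon, has no ring and carries a hydroxyl hydrogen-bond donor, so several features change at once and the compounds cannot separate them. No measurement shown explains the large rise in the number.

From the compounds shown here alone, it remains open whether the hydroxyl itself matters, which a tert-butyl group, the same branched carbon framework without the hydroxyl, would test. Going by these compounds, it is equally open whether a simple dimethylamino group or a longer chain such as 4-hydroxybutyl at this aromatic carbon would return the number to the level of compound 1 and compound 2.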